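The source may hold more compounds than are shown below. What is called first, only, known or untested is meant among the compounds shown, and "the series" means these compounds.

Measured in a functional assay on K562 cells (Homo sapiens) for antiproliferative activity, read by CellTiter-Glo, with a stated time of 72 h; a higher number here means that more compound is needed for the effect, a lower number that less compound is needed:
- compound 1 `CCCCCCNc1ncnc2c1ncn2[C@@H]1O[C@H](COS(N)(=O)=O)[C@@H](O)[C@H]1O`: 160 nM
- compound 2 `CC(C)(C)CC(C)(C)Nc1ncnc2c1ncn2[C@@H]1O[C@H](COS(N)(=O)=O)[C@@H](O)[C@H]1O`: > 1000 nM

Compound 2 has a limit and not a number: the limit of > 1000 nM in this assay, at which 1 of the 2 values shown sits.

Compound 3 `CCC(C)Nc1ncnc2c1ncn2[C@@H]1O[C@H](COS(N)(=O)=O)[C@@H](O)[C@H]1O` carries sec-butyl in place of 1,1,3,3-tetramethylbutyl on a nitrogen on an aromatic ring.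

For the measured compounds named here, one measured step bears on this change, an at least 6.2-fold higher number from compound 1 to compound 2 (0.79 log units; beyond the scatter). Going by the values given here, with that step as the only guide, a move back towards compound 1 is expected, to a lower number in this assay and of similar size: the expected step is an at least 4.0-fold lower number from compound 2 to compound 3 (0.60 log units; beyond the scatter). For compound 3 the estimate is 250 nM, with an expected range of 70 nM to 900 nM.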

Compound 3, half-maximal effective concentration: > 1000 nM
Compound 3 gave a limit, no number; the forecaster's own chance of this, stated with the estimate: 15%; middle value at least 4.0-fold (0.60 log units) from the limit.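

In this assay, the smaller branched group also gives no measurable value: compound 3 stands at a limit, > 1000 nM. The change from hexyl to sec-butyl gives an at least 6.2-fold higher number from compound 1 to compound 3 (0.79 log units; beyond the scatter), so among these three compounds a measured value occurs only with the unbranched hexyl chain. The step between the two branched compounds cannot be read: the limit of > 1000 nM in this assay, at which 2 of the 3 values shown sit.

As far as these compounds go, how far compound 2 and compound 3 lie beyond that limit remains open. Also open, from the compounds shown here alone, is whether butyl, octyl or cyclohexyl on the same nitrogen would give a measured value, which would separate chain length from branching.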